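The source may hold more compounds than are shown below. What is called first, only, known or untested is meant among the compounds shown, and "the series" means these compounds.

Measured in an in vitro assay on BTI-TN-5B1-4 cells for inhibition of Amine oxidase [flavin-containing] B (Homo sapiens), read by fluorescence, with a stated time of 15 min; a lower number here means a stronger inhibitor, a higher number a weaker inhibitor:
compound 1 `CCOC(=O)c1cc2ccc(N(CC)CC)cc2oc1=O` gives 45500 nM
compound 2 `NNC(=O)c1cc2ccccc2oc1=O` gives 3.22 nM
compound 3 `O=C(NNc1ccccc1)c1cc2ccccc2oc1=O` gives 4520 nM

Compound 3 holds the second highest of these three numbers. Its nearest neighbour is compound 1, which lies higher, and its furthest is compound 2, which lies far lower. Going by the values given here, the only single change among the measured compounds is the step of a 1400-fold higher number from compound 2 to compound 3 (3.15 log units; beyond the scatter), in which a phenyl ring took the place of a hydrogen on an amine nitrogen.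

Compound 4 `O=C(NNc1ccc(Cl)cc1)c1cc2ccccc2oc1=O` has not yet been measured. It differs from compound 3 by chloro in place of hydrogen on an aromatic carbon, the new atom sitting on an aromatic carbon of a six-membered aromatic ring of carbon only, para to a large group; seen one bond further out, the phenyl becomes a 4-chlorophenyl.

Among the compounds with values here, no measured step speaks directly to this change. The step from compound 2 to compound 3 concerns the arrival of the phenyl ring itself, not a substituent on it, so it gives no guide to what a chlorine on that ring will do. With nothing else to go on, the expected step of a 1.1-fold lower number from compound 3 to compound 4 (0.05 log units; within the scatter) is taken as none beyond the scatter. Compound 4 is therefore estimated at 4000 nM in this assay, with a range from 1200 nM to 13000 nM that allows for a moderate move either way.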

Compound 4, half-maximal inhibitory concentration: 1190 nM
Beside the measured number, compound 4's estimate is 3.4-fold (0.53 log units) above it, outside the stated range (below it).
By their numbers in this assay, from the lowest: compound 2; then compound 4; then compound 3; then compound 1.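

In this assay the phenyl ring of compound 3 proves open to change: a chloro in place of hydrogen on the aromatic carbon para to a large group gives a 3.8-fold lower number from compound 3 to compound 4 (0.58 log units; beyond the scatter) and so moves the number beyond the scatter, though only modestly. This gain recovers only a small part of what the ring cost in a 1400-fold higher number from compound 2 to compound 3 (3.15 log units; beyond the scatter), as a 370-fold higher number from compound 2 to compound 4 (2.57 log units; beyond the scatter) remains when 4-chlorophenyl replaces hydrogen on the amine nitrogen, and compound 2 therefore keeps by far the lower number of the three. No measurement shown bears on why the chlorine lowers the number.

As far as these compounds go, whether the same step would come with a bromo, a methyl or a methoxy group on that carbon stays open, as does what a chloro would do on another carbon of the ring. Also open, from the compounds shown here alone, is whether a methyl group in place of the ring on that amine nitrogen would keep the number closer to that of compound 2.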